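Extending the Urea into a Semicarbazide on a Quinoline Core

The compounds below may be only part of what the source reports. "The series", "measured", "known", "first", "only" and "open" are said of these compounds alone.

Measured so far:
- compound 1, `COc1cc(NC(C)CCCNC(=O)Nc2ccc(Br)cc2)c2ncccc2c1`: 23000 nM
- compound 2, `COc1cc(NC(C)CCCNC(=O)Nc2cccc(C(F)(F)F)c2)c2ncccc2c1`: 17000 nM
- compound 3, `COc1cc(NC(C)CCCNC(=O)NNC(=O)Nc2cccc(C(F)(F)F)c2)c2ncccc2c1`: 5600 nM

In a functional assay on MIA PaCa-2 cells (Homo sapiens) for inhibition, read by MTT assay, with a stated time of 72 h (on this read-out lower numbers stand for stronger inhibition and higher numbers for weaker inhibition), compound 1 gives the highest of the three numbers. Compound 2 lies nearest, a 1.4-fold lower number from compound 1 to compound 2 (0.13 log units; within the scatter). Compound 3 lies furthest from compound 1, and its value shows that the longer linker in compound 3 goes with a lower number than compound 2 carries.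

Compound 4, `COc1cc(NC(C)CCCNC(=O)NNC(=O)Nc2cccc(Cl)c2)c2ncccc2c1`, is not yet measured. It differs from compound 1 by ((3-chlorophenyl)carbamoyl)amino in place of 4-bromophenyl on an amide-type nitrogen. Because a 1.4-fold lower number from compound 1 to compound 2 (0.13 log units; within the scatter) was within the scatter, the change of the aryl group alone is not expected to move the number; the values of compound 2 and compound 3 suggest that the inserted carbamoylamino unit does. Compound 4 is therefore expected to show a 3.5-fold lower number from compound 1 to compound 4 (0.55 log units; beyond the scatter), a clearly lower number. The estimate for compound 4 is 6500 nM, expected between 3000 nM and 14000 nM.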

Compound 4, half-maximal inhibitory concentration: 74000 nM
Estimate against measurement, compound 4: 11-fold (1.06 log units) below; measured number outside the range, above it.
By their numbers in this assay, from the lowest: compound 3; then compounds 2 and 1 (each within the scatter of the next); then compound 4.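

In this assay, the longer ((3-chlorophenyl)carbamoyl)amino arm does not lower the number on its own: it gives a 3.2-fold higher number from compound 1 to compound 4 (0.51 log units; beyond the scatter) and a 4.4-fold higher number from compound 2 to compound 4 (0.64 log units; beyond the scatter). On this longer arm the aromatic substituent matters, with chloro in place of trifluoromethyl giving a 13-fold higher number from compound 3 to compound 4 (1.12 log units; beyond the scatter). No measurement here explains this difference.

On these data alone, it remains open whether a nitrile or a methyl on that aromatic carbon would give a number closer to that of compound 3 or compound 4. Also open, as far as these compounds go, is how a 3-chlorophenyl group behaves on the shorter urea arm.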